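Triazole aryl variation in a diaryl urea HepG2 series

A few compounds are considered here, and "the series" means these few. Any claim that something is new, unique, unknown or untested is made for them only; others in the source may bear on it.

Measured compounds:
compound 1 `COc1cccc(-n2cc(COc3cccc(NC(=O)Nc4ccc(Cl)c(C(F)(F)F)c4)c3)nn2)c1`, 1310 nM
compound 2 `CCc1cccc(-n2cc(COc3cccc(NC(=O)Nc4ccc(Cl)c(C(F)(F)F)c4)c3)nn2)c1`, 37900 nM
compound 3 `CCc1ccc(-n2cc(COc3cccc(NC(=O)Nc4ccc(Cl)c(C(F)(F)F)c4)c3)nn2)cc1`, 1950 nM

In a functional assay on HepG2 cells (Homo sapiens) for inhibition, read by MTT assay, with a stated time of 72 h (a higher number here means a weaker inhibitor, a lower number a stronger inhibitor), compound 3 stands second highest of the three numbers; it sits close to compound 1 and far from compound 2. The steps to it: a 1.5-fold higher number from compound 1 to compound 3 (0.17 log units; within the scatter), a change within the scatter, and a 19-fold lower number from compound 2 to compound 3 (1.29 log units; beyond the scatter), a large improvement. The aryl group on the triazole nitrogen therefore matters greatly, the 3-ethylphenyl of compound 2 being far worse than either the 3-methoxyphenyl of compound 1 or the 4-ethylphenyl of compound 3.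

Compound 4 `O=C(Nc1cccc(OCc2cn(-c3ccccc3F)nn2)c1)Nc1ccc(Cl)c(C(F)(F)F)c1` carries a (2-fluorophenyl in place of 4-ethylphenyl on an aromatic nitrogen). Among the measured compounds shown here, no measured compound carries a 2-fluorophenyl, so the step has no direct precedent; the measured steps show only that the aryl on the triazole nitrogen can shift the number by a large amount in either direction. Compound 4 is therefore expected to land near compound 3 but with wide uncertainty, a 1.5-fold higher number from compound 3 to compound 4 (0.19 log units; within the scatter). The estimated value for compound 4 is 3000 nM, within a range of 600 nM to 20000 nM.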

Compound 4, half-maximal inhibitory concentration: 1520 nM
Compound 4: the middle estimate sits 2.0-fold (0.30 log units) above what was measured; measured number inside the range.
By their numbers in this assay, from the lowest: compounds 1, 4 and 3 (each within the scatter of the next); then compound 2.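

In this assay, the 2-fluorophenyl group on the aromatic nitrogen does not separate from the 4-ethylphenyl (a 1.3-fold lower number from compound 3 to compound 4 (0.11 log units; within the scatter)) or from the 3-methoxyphenyl (a 1.2-fold higher number from compound 1 to compound 4 (0.06 log units; within the scatter)), so a fluorine-bearing aryl of 7 heavy atoms joins the same band as the two larger aryl groups. The 3-ethylphenyl of compound 2 stays apart from this new aryl as well (a 25-fold lower number from compound 2 to compound 4 (1.40 log units; beyond the scatter)), which makes compound 2 the single exception among the four rather than one end of a graded spread. Nothing on hand accounts for that exception.

Going by these compounds, whether the large loss belongs to the 3-ethylphenyl alone or extends to other groups on the aryl remains open. Also open, on these data alone, is whether an amine, a carboxylic acid or a longer chain such as butyl on that aryl would stay in the same band.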